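Swapping 4-Chlorobenzyl for 2-Methoxybenzyl in Compound 2

A few compounds are considered here, and "the series" means these few. Any claim that something is new, unique, unknown or untested is made for them only; others in the source may bear on it.

Measured in a functional assay on MIA PaCa-2 cells (Homo sapiens) for inhibition, read by MTT assay, with a stated time of 72 h; a lower number here means a stronger inhibitor of growth, a higher number a weaker inhibitor of growth:
compound 1 `CC(C)(C)c1ccc(CNCCNS(=O)(=O)c2cc(C(F)(F)F)cc(C(F)(F)F)c2)cc1` gives 15000 nM;
compound 2 `O=S(=O)(NCCCNCc1ccc(Cl)cc1)c1cc(C(F)(F)F)cc(C(F)(F)F)c1` gives 2800 nM;
compound 3 `O=S(=O)(NCCCCCCNCc1ccc(Br)cc1)c1ccccc1F` gives 13300 nM.

Compound 2 has the lowest number of the three in this assay, beyond the scatter from both compound 3 and compound 1. The unmeasured compound 4 `COc1ccccc1CNCCCNS(=O)(=O)c1cc(C(F)(F)F)cc(C(F)(F)F)c1` shares the core of compound 2 and differs from it in one place: 2-methoxyphenyl in place of 4-chlorophenyl on a saturated chain carbon bound to an amine nitrogen. Within the data shown here, no measured pair shows this change, so its effect cannot be read from the data. The step of a 1.8-fold higher number from compound 2 to compound 4 (0.25 log units; within the scatter) is expected to be small, toward a slightly higher number if anything, and may fall within the scatter. Compound 4 is therefore estimated at 5000 nM, with a range from 2000 nM to 15000 nM.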

Compound 4, concentration for 50% growth inhibition: 3100 nM
Beside the measured number, compound 4's estimate is 1.6-fold (0.21 log units) above it; measured number inside the range.
By their numbers in this assay, from the lowest: compounds 2 and 4 (each within the scatter of the next); then compounds 3 and 1 (each within the scatter of the next).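

In this assay, 2-methoxyphenyl in place of 4-chlorophenyl on a saturated chain carbon bound to an amine nitrogen gives a 1.1-fold higher number from compound 2 to compound 4 (0.04 log units; within the scatter). Among these compounds, this is the first single-place comparison, and it shows that this change, which brings in a hydrogen-bond acceptor and removes the chlorine, leaves the growth-inhibition number unchanged within the scatter. Nothing available explains this result. From the compounds shown here alone, whether a phenyl group carrying a carboxylic acid or a nitrile would give a similar number remains open. So does whether this swap behaves the same way on a longer chain.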